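Working notes on cytotoxicity across a three-compound series

The source may report more compounds than this note shows. Statements on the series, on what has been measured and on what is new or still open speak of the compounds shown alone.

Measured so far:
compound 1, `COC(=O)CNC1=CS(=O)(=O)O[C@@]12[C@@H](CO[Si](C)(C)C(C)(C)C)O[C@@H](n1cc(C)c(=O)n(C)c1=O)[C@@H]2O[Si](C)(C)C(C)(C)C`: >= 400000 nM
compound 2, `Cc1cn([C@@H]2O[C@H](CO[Si](C)(C)C(C)(C)C)[C@@]3(OS(=O)(=O)C=C3NCC(=O)C(N)=O)[C@H]2O[Si](C)(C)C(C)(C)C)c(=O)n(C)c1=O`: >= 16000 nM

In a functional assay on HEL cells (Homo sapiens) for cytotoxicity, read by microscopy (on this read-out lower numbers stand for higher toxicity in this test and higher numbers for lower toxicity in this test), compound 1 gives >= 400000 nM, a limit of the assay rather than a number. Compound 2 gives >= 16000 nM in this assay, again a limit and not a number. Going by the values given here, the only measured step, a step that the two limits leave unreadable from compound 1 to compound 2, is therefore not readable in size or direction; the two limits the limit of >= 16000 nM in this assay, at which 1 of the 2 values shown sits, and the limit of >= 400000 nM in this assay, at which 1 of the 2 values shown sits, are all that stands for it.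

Compound 3, `COC(=O)CCNC1=CS(=O)(=O)O[C@@]12[C@@H](CO[Si](C)(C)C(C)(C)C)O[C@@H](n1cc(C)c(=O)n(C)c1=O)[C@@H]2O[Si](C)(C)C(C)(C)C`, is the next member. It differs from compound 2 by (methoxycarbonyl)methyl in place of carbamoylcarbonyl on a saturated chain carbon bound to an amine nitrogen, so that compound 3 carries a (methoxycarbonyl)ethyl chain of the kind compound 1 carries as a (methoxycarbonyl)methyl chain. Among the compounds with values here, the one step that bears on this change is unreadable, so no size can be taken from it. The expectation rests on compound 1 giving >= 400000 nM with a chain of the same kind: compound 3 is expected to show no measurable toxicity and to return a limit as well. The expected step is a step that the limit leaves unreadable from compound 2 to compound 3. For compound 3 the estimate in this assay is 200000 nM, between 50000 nM and 800000 nM.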

Compound 3, minimum cytotoxic concentration: >= 400000 nM
Compound 3 gave a limit, no number; the forecaster's own chance of this, stated with the estimate: 85%; middle value at least 2.0-fold (0.30 log units) away from the limit.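

No new step can be read in this assay among compound 1, compound 2 and compound 3: all three values are limits of the assay, not numbers. What remains open is the size and direction of each chain change's effect on toxicity in this test, and the concentration at which any of these compounds would register as toxic.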